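A few compounds are considered here, and "the series" means these few. Any claim that something is new, unique, unknown or untested is made for them only; others in the source may bear on it.

Of the compounds shown here, two share the same trimethoxybenzyl core and have been tested in a functional assay on MCF7 cells (Homo sapiens) for antiproliferative activity; a higher number here means a weaker inhibitor, a lower number a stronger inhibitor. Compound 1 `C#CCCCn1c(Cc2cc(OC)c(OC)c(OC)c2)nc2c(N)nc(F)nc21` gives 11000 nM in this assay, while compound 2 `COc1cc(Cc2nc3c(N)ncnc3n2CC2CCCCC2)cc(OC)c1OC` gives 39800 nM, the higher of the two numbers, a gap beyond the scatter. Compound 3 `CCC(C)Cn1c(Cc2cc(OC)c(OC)c(OC)c2)nc2c(N)ncnc21` differs from compound 2 by a single replacement: sec-butyl in place of cyclohexyl on a saturated chain carbon bound to an aromatic nitrogen. Within the data shown here, with no measured pair tracing this change, only a modest step is expected, if any, toward a lower number; the expected step is a 1.6-fold lower number from compound 2 to compound 3 (0.20 log units; within the scatter). Compound 3 is therefore estimated at 25000 nM, within a range from 8000 nM to 80000 nM.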

Compound 3, half-maximal inhibitory concentration: 61700 nM
Compound 3: middle estimate off by 2.5-fold (0.39 log units), on the low side; low and high end bracket the measured number.
By their numbers in this assay, from the lowest: compound 1; then compounds 2 and 3 (each within the scatter of the next).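

In this assay, sec-butyl in place of cyclohexyl on a saturated chain carbon bound to an aromatic nitrogen gives a 1.6-fold higher number from compound 2 to compound 3 (0.19 log units; within the scatter), so compound 2 and compound 3 cannot be told apart. This pair shows that the six-membered ring of carbon can give way to an open carbon chain here without a change beyond the scatter. Nothing available explains this result. As far as these compounds go, both groups hold carbon only, so it remains open whether an amine or a carboxylic acid at this place would move the number beyond the scatter.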